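A few compounds are considered here, and "the series" means these few. Any claim that something is new, unique, unknown or untested is made for them only; others in the source may bear on it.

Three compounds share one core, each carrying an aryl group on an amide-type ring nitrogen. Compound 1 `O=C1N/C(=C\c2ccc(O)cc2)C(=O)N1c1ccc(I)cc1` is measured in a functional assay on NCI-H292 cells (Homo sapiens) for antiproliferative activity (on this read-out higher numbers stand for weaker inhibition and lower numbers for stronger inhibition), where compound 1 gives 25500 nM. Compound 2 `O=C1N/C(=C\c2ccc(Br)cc2)C(=O)N1c1ccc(Cl)cc1` gives 46600 nM, and compound 3 `COc1ccc(/C=C2\NC(=O)N(c3ccc(Cl)cc3)C2=O)cc1` gives 32100 nM. Compound 1 has the lowest of these three numbers, but both gaps to it lie within the usual scatter, so no ranking can be read from them. Among the compounds with values here, the only single-site step, a 1.5-fold lower number from compound 2 to compound 3 (0.16 log units; within the scatter), alters a group on an aromatic carbon, not the group on the ring nitrogen. Compound 4 `Cc1cccc(N2C(=O)N/C(=C\c3ccc(O)cc3)C2=O)c1` differs from compound 1 by 3-methylphenyl in place of 4-iodophenyl on an amide-type nitrogen in a ring. Within the data shown here, no measured step touches that position, so the expected step is a 1.2-fold higher number from compound 1 to compound 4 (0.07 log units; within the scatter), nothing beyond the scatter. Compound 4 is therefore estimated at 30000 nM, ranging from 10000 nM to 90000 nM.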

Compound 4, half-maximal inhibitory concentration: > 200000 nM
Compound 4 was reported as a limit; the forecaster's own chance of this, stated with the estimate: 10%; middle value at least 6.6-fold (0.82 log units) from the limit.
By their numbers in this assay, from the lowest: compounds 1, 3 and 2 (each within the scatter of the next). At a limit, above all of these: compound 4.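

Within the data shown here, replacing 4-iodophenyl with 3-methylphenyl on the amide-type ring nitrogen gives an at least 7.8-fold higher number from compound 1 to compound 4 (0.89 log units; beyond the scatter), so this position can move the read-out beyond the scatter, which no earlier step showed. Compound 4 is reported as a limit, not a number: the limit of > 200000 nM in this assay, at which 1 of the 4 values shown sits. The two groups are alike in the counts computed, each with 7 heavy atoms and one aromatic carbon ring, so those counts do not separate them.

The swap changes both the substituent and its place on the phenyl ring, and the compounds shown cannot tell these two changes apart. On these data alone, how an amine or a carboxylic acid on that ring would read remains open.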